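Aryl swap on the triazole nitrogen: outlook for compound 4

The source may report more compounds than this note shows. Statements on the series, on what has been measured and on what is new or still open speak of the compounds shown alone.

Among the measured compounds shown here, the series shares one core, seen in compound 1 `Cc1cccc(-n2nncc2CN2C(=O)C3(C(C#N)=C(N)Oc4c3c3nc5ccccc5nc3c3ccccc43)c3ccccc32)c1`, and the three measured members differ only in the aryl group on an aromatic nitrogen. In a functional assay on A549 cells (Homo sapiens) for antiproliferative activity, read by MTT assay, with a stated time of 48 h (on this read-out higher numbers stand for weaker inhibition and lower numbers for stronger inhibition), compound 1 gives 39600 nM. Compound 2 `N#CC1=C(N)Oc2c(c3nc4ccccc4nc3c3ccccc23)C12C(=O)N(Cc1cnnn1-c1ccc(F)cc1)c1ccccc12` carries 4-fluorophenyl in that position; in this assay compound 2 reaches only a limit, > 50000 nM. Compound 3 `COc1ccc(-n2nncc2CN2C(=O)C3(C(C#N)=C(N)Oc4c3c3nc5ccccc5nc3c3ccccc43)c3ccccc32)cc1` carries 4-methoxyphenyl and likewise gives only a limit in this assay, > 50000 nM. The readable steps are an at least 1.2-fold higher number from compound 1 to compound 2 (0.10 log units; that floor lies within the scatter) and an at least 1.2-fold higher number from compound 1 to compound 3 (0.10 log units; that floor lies within the scatter); the step that the two limits leave unreadable from compound 2 to compound 3 cannot be sized because of the limit of > 50000 nM in this assay, at which 2 of the 3 values shown sit.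

Compound 4 `Cc1ccc(Cl)cc1-n1nncc1CN1C(=O)C2(C(C#N)=C(N)Oc3c2c2nc4ccccc4nc2c2ccccc32)c2ccccc21` is the next variant on the same nitrogen: 5-chloro-2-methylphenyl in place of 4-fluorophenyl on an aromatic nitrogen. The two steps that bear on it, from compound 1 to compound 2 and from compound 1 to compound 3, both sit at a floor that lies within the scatter, so no aryl change shown so far has moved the number in this assay beyond it, and the two limits leave any further movement unreadable. The expected step is therefore a number no higher from compound 2 to compound 4 (the limit leaves the size open), that is, nothing beyond the scatter, with a real chance that this assay again returns only a limit. For compound 4 the estimate is 50000 nM, with a range from 25000 nM to 100000 nM.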

Compound 4, half-maximal inhibitory concentration: > 50000 nM
Compound 4: no number, only a limit; the forecaster's own chance of this, stated with the estimate: 60%; the middle value lies on the limit itself.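

With 5-chloro-2-methylphenyl on the aromatic nitrogen, the series now includes an aryl carrying both a chloro and a methyl group, yet in this assay compound 4 again gives only a limit, > 50000 nM. Among the compounds shown here, the one readable step is an at least 1.2-fold higher number from compound 1 to compound 4 (0.10 log units; that floor lies within the scatter), so this aryl change, like the other two readable ones, shows nothing beyond the scatter. The steps to compound 4 from compound 2 and from compound 3 cannot be read, because both ends of each step are limits: the limit of > 50000 nM in this assay, at which 3 of the 4 values shown sit.

How compound 2, compound 3 and compound 4 stand relative to one another remains unknown, and the aryl groups shown give no sign of any group on this nitrogen that would bring a reading clearly under the limit. Also open, as far as these compounds go, is whether a phenyl bearing an amine or a carboxylic acid, or a longer alkyl chain in place of the aryl group, would give a step beyond the scatter in this assay.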